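Cytotoxicity notes: aryl in place of butyl on the triazole

The source may report more compounds than this note shows. Statements on the series, on what has been measured and on what is new or still open speak of the compounds shown alone.

Measured so far:
compound 1 `CCCCCc1ccc(-c2cn(C/C=C3\OC(=O)C(OCc4ccccc4)=C3OCc3ccccc3)nn2)cc1`: > 100000 nM
compound 2 `CCCCc1cn(C[C@H](O)[C@H]2OC(=O)C(OCc3ccccc3)=C2OCc2ccccc2)nn1`: 26300 nM

Among the measured compounds shown here, in an ADME assay on HFF cells (Homo sapiens) for cytotoxicity, read by MTT assay, with a stated time of 72 h (a higher number here means a weaker inhibitor, a lower number a stronger inhibitor), compound 2 gives 26300 nM, the only proper number in the set. Compound 1 is recorded only as a limit, > 100000 nM, and so cannot be placed on the scale; the relevant boundary is the limit of > 100000 nM in this assay, at which 1 of the 2 values shown sits. Compound 2 therefore stands alone as the single measured reference point.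

Compound 3 `Cc1ccc(-c2cn(C[C@H](O)[C@H]3OC(=O)C(OCc4ccccc4)=C3OCc3ccccc3)nn2)cc1` is the next candidate. Relative to compound 2 the change is 4-methylphenyl in place of butyl on an aromatic carbon, so 4-methylphenyl replaces butyl on an aromatic carbon. For the measured compounds named here, no measured pair shows this kind of exchange, so no direction can be read from the data; the step of a 1.5-fold higher number from compound 2 to compound 3 (0.18 log units; within the scatter) is expected to be small, at most a little beyond the scatter, and if anything toward weaker cytotoxicity. Compound 3 is expected to give 40000 nM, with a range of 15000 nM to 100000 nM, and a real chance that only a limit is returned.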

Compound 3, half-maximal inhibitory concentration: > 100000 nM
Compound 3: no number, only a limit (the forecaster's own chance of this, stated with the estimate: 30%); at least 2.5-fold (0.39 log units) between middle value and limit.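

The exchange of butyl for 4-methylphenyl on an aromatic carbon of the five-membered aromatic ring now has a measured direction, toward weaker cytotoxicity: an at least 3.8-fold higher number from compound 2 to compound 3 (0.58 log units; beyond the scatter). In this assay compound 3 gives > 100000 nM, which is a limit and not a number. The step therefore gives only a lower bound on the size of the change, and the top of the measurable range now holds most of the series: the limit of > 100000 nM in this assay, at which 2 of the 3 values shown sit.

Still open, on these data alone, is whether the shift follows from the aromatic ring itself or simply from a larger group, which a longer chain such as octyl at the same carbon could help separate from 4-methylphenyl. Also open, as far as these compounds go, is how an amine or a carboxylic acid on the phenyl ring would read out, and whether any group at this carbon gives stronger cytotoxicity than butyl.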